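A few compounds are considered here, and "the series" means these few. Any claim that something is new, unique, unknown or untested is made for them only; others in the source may bear on it.

Among the compounds with values here, in a functional assay on U-937 cells (Homo sapiens) for cytotoxicity, read by MTT assay, with a stated time of 24 h (a lower number here means a stronger inhibitor, a higher number a weaker inhibitor), three compounds have numbers so far. Compound 1 (`COc1cc2nc(Cl)nc(NS(=O)(=O)c3cccs3)c2cc1OC`) gives 10.1 ug/mL and sits within the usual scatter of compound 3 (`COc1cc2nc(N3CCCC3)nc(NS(=O)(=O)C3CC3)c2cc1OC`), which gives 6.43 ug/mL and cannot be told apart from it. Compound 2 (`COc1cc2nc(Cl)nc(NS(=O)(=O)c3cccc(C(F)(F)F)c3)c2cc1OC`) gives 59.1 ug/mL and stands beyond the scatter from compound 1, with a higher number.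

The step followed here leads to compound 4 (`COc1cc2nc(Cl)nc(NS(=O)(=O)c3ccc(C)cc3)c2cc1OC`), with 4-methylphenyl in place of thiophen-2-yl on a sulfonyl sulfur. Within the data shown here, no pair of measured compounds differs in one place only, so this change has no direct precedent in the data. The nearest guide is compound 2, which also has a six-membered aromatic ring of carbon only on the sulfonyl sulfur and gives 59.1 ug/mL in this assay while also differing from compound 4 in what that ring carries. On that single comparison, a move to a higher number is expected, though a smaller one than compound 2 shows and possibly not far beyond the scatter. The expected size is a 2.4-fold higher number from compound 1 to compound 4 (0.38 log units; beyond the scatter) in this estimate. For compound 4 the estimated value is 24 ug/mL with an expected range from 8 ug/mL to 70 ug/mL in this assay overall.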

Compound 4, half-maximal inhibitory concentration: 39.9 ug/mL
Beside the measured number, compound 4's estimate is 1.7-fold (0.22 log units) below it; low and high end bracket the measured number.
By their numbers in this assay, from the lowest: compounds 3 and 1 (each within the scatter of the next); then compounds 4 and 2 (each within the scatter of the next).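

In this assay, within the data shown here, replacing thiophen-2-yl with 4-methylphenyl on a sulfonyl sulfur gives the first step in which only this group changes, a 4.0-fold higher number from compound 1 to compound 4 (0.60 log units; beyond the scatter). It shows directly that the number responds to what the sulfonyl sulfur carries when the rest of the molecule stays the same. Compound 4 also lies within the scatter of compound 2, so the two compounds shown with a six-membered aromatic ring of carbon only at this place cannot be told apart, although their rings carry different groups; no measurement given here explains the step.

The compounds shown leave open whether the higher number goes with the change of ring or with the methyl group it carries, a question that a plain phenyl ring at this place would help to separate. On these data alone, it also remains open how a cyclopropyl group on the sulfonyl sulfur would read on the core of compound 1, as compound 3 carries that group together with a pyrrolidine ring in place of the chlorine.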